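Furyl dihydropyrimidinone series: ethyl on the amide nitrogen

This account rests on a few compounds, and the source may have more. Where it says the series, first, only, none or still open, it means among the compounds named here.

Compound 3 `CCNC(=O)C1=C(C)NC(=O)NC1c1ccco1` sits, together with compound 1, at the low end of the three numbers in an assay on membranes from HeLa cells for displacement of a labelled ligand from adenosine receptor A3 (Homo sapiens), read by scintillation counting, with a stated time of 180 min, tested at 1 uM; on this read-out higher numbers stand for more inhibition at the one concentration tested (going by the name of the read-out) and lower numbers for less inhibition: compound 3 gives 3%, and compound 1 `CCCOC(=O)C1=C(C)NC(=O)NC1c1ccco1` gives 3%, the two being level, as no change at the digits printed from compound 1 to compound 3 (within the scatter) shows. Compound 2 `CC1=C(C(=O)CC(C)C)C(c2ccco2)NC(=O)N1` stands apart with 31%, the gap being a number 28 percentage points lower from compound 2 to compound 3 (beyond the scatter).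

Compound 4 `CCN(CC)C(=O)C1=C(C)NC(=O)NC1c1ccco1` carries ethyl in place of hydrogen on an amide-type nitrogen. For the measured compounds named here, no measured step touches the amide nitrogen; the known steps all vary the group on the carbonyl carbon, and both the ester and the secondary amide there sit low, only the ketone of compound 2 rising. With nothing pointing either way, compound 4 is expected to stay at the low end, the estimated step of a number 3 percentage points higher from compound 3 to compound 4 (within the scatter) being none beyond the scatter. The estimate for compound 4 is 6%, with a range from 0% to 22%.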

Compound 4, a percentage reported as inhibition, at one concentration (the size of the read-out at that concentration, not a potency): 19%
Compound 4: the middle estimate sits 13 percentage points below what was measured, within the range that was stated.
By their numbers in this assay, from the lowest: compounds 1 and 3 (each within the scatter of the next); then compound 4; then compound 2.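

In this assay the amide nitrogen proves to be a position that responds: ethyl in place of hydrogen gives a real rise (a number 16 percentage points higher from compound 3 to compound 4 (beyond the scatter)), whereas ethylamino in place of propoxy had left the number flat. The diethylamino group also stands clear of the propoxy ester (a number 16 percentage points higher from compound 1 to compound 4 (beyond the scatter)) but does not reach the isobutyl ketone (a number 12 percentage points lower from compound 2 to compound 4 (beyond the scatter)), which places it in the middle of the series. No evidence on the reason for this order is at hand.

Still open, from the compounds shown here alone, is whether longer chains on the amide nitrogen, such as two propyl groups, or a cyclic amine such as piperidine would move the number further.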